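The source may report more compounds than this note shows. Statements on the series, on what has been measured and on what is new or still open speak of the compounds shown alone.

Compound 2 `CC(CSc1nnc(-c2ccncc2)s1)C(=O)Nc1ccc(Cl)cc1` and compound 1 `O=C(CCSc1nnc(-c2ccncc2)s1)Nc1ccc(Cl)cc1` share one core and differ by hydrogen in place of methyl on a saturated chain carbon bound to a carbonyl carbon and a saturated chain carbon. In an ADME assay on BHK-21 cells (Mesocricetus auratus) for cytotoxicity, with a stated time of 3 days (on this read-out lower numbers stand for higher toxicity in this test and higher numbers for lower toxicity in this test), compound 1 gives 8210 nM. For compound 2 the same test reports only a limit, > 50000 nM. The step between them is an at least 6.0-fold lower number from compound 2 to compound 1 (0.78 log units; beyond the scatter), and because of the limit of > 50000 nM in this assay, at which 2 of the 3 values shown sit, only a lower bound on its size is known. Compound 3 `CC(CSc1nnc(-c2ccncc2)s1)C(=O)NCc1ccccc1` differs from compound 2 by benzyl in place of 4-chlorophenyl on an amide-type nitrogen. For compound 3 this assay again reports only a limit, > 50000 nM. The step that the two limits leave unreadable from compound 2 to compound 3 therefore cannot be read. Compound 4 `O=C(CCSc1nnc(-c2ccncc2)s1)NCc1ccccc1` differs from compound 3 by hydrogen in place of methyl on a saturated chain carbon bound to a carbonyl carbon and a saturated chain carbon, the same change made from compound 2 to compound 1. Resting on an at least 6.0-fold lower number from compound 2 to compound 1 (0.78 log units; beyond the scatter), compound 4 is expected to give a lower number than the limit of compound 3. Compound 4 is estimated at 15000 nM, between 6000 nM and 50000 nM, an expected step of an at least 3.3-fold lower number from compound 3 to compound 4 (0.52 log units; beyond the scatter).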

Compound 4, half-maximal cytotoxic concentration: 18700 nM
The estimate for compound 4 lay 1.2-fold (0.10 log units) below the measured number, within the range that was stated.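

In this assay, hydrogen in place of methyl lowers the number on both cores, and with benzyl on the amide nitrogen the step is an at least 2.6-fold lower number from compound 3 to compound 4 (0.42 log units; beyond the scatter). The direction of the change therefore carries from one core to the other: the same change on two cores in this assay, an at least 6.0-fold lower number (0.78 log units; beyond the scatter) from compound 2 to compound 1 and an at least 2.6-fold lower number (0.42 log units; beyond the scatter) from compound 3 to compound 4; the limit leaves it open whether they differ. From the compounds shown here alone, whether its size also carries over stays unknown, because both methyl compounds sit at a limit of the assay: the limit of > 50000 nM in this assay, at which 2 of the 4 values shown sit.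

With hydrogen on the chain, benzyl in place of 4-chlorophenyl gives a 2.3-fold higher number from compound 1 to compound 4 (0.36 log units; beyond the scatter), whereas the same swap with the methyl present cannot be read. The compounds shown leave open what a longer chain, such as ethyl, or an amine in place of that methyl would give.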